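Amide series: whole-organism inhibition at a single dose

This account rests on a few compounds, and the source may have more. Where it says the series, first, only, none or still open, it means among the compounds named here.

compound 1, `NC(=O)/C=C1\CCc2cc(Cl)ccc21`: 0%
compound 2, `O=C(/C=C1\CCc2ccc(F)cc21)NC1CCCC1`: 0%

Both measured compounds were run in a functional assay on the whole organism with Mus musculus as the target, at a dose of 100 mg/kg by the intraperitoneal route; a higher number here means more inhibition at the dose given (going by the name of the read-out), a lower number less inhibition. Compound 1 gives 0%, and compound 2 gives 0%. Compound 2 therefore stands level with compound 1 at the digits shown; its nearest neighbour is compound 1, with no change between them within the scatter.

Compound 3, `O=C(/C=C1\CCc2ccc(F)cc21)NC1CCC1`, has not yet been measured in this assay. It differs from compound 2 in one place: cyclobutyl in place of cyclopentyl on an amide-type nitrogen. The cyclopentyl leaves and the cyclobutyl enters, with no change in hydrogen-bond donors, acceptors or charge.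

Among the measured compounds shown here, no step between two measured compounds has been reported, so no direction can be taken from the series itself. Since compound 1 and compound 2 both show no inhibition, the step expected no change at the digits printed from compound 2 to compound 3 (within the scatter) is none beyond the scatter. For compound 3 the estimated read-out in this assay is 0%, with a range from 0% to 10%.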

Compound 3, a percentage reported as inhibition, in the whole organism at one dose (the size of the read-out at that dose, not a potency): 100%
Estimate against measurement, compound 3: 100 percentage points below; the whole stated range lies below it.
By their numbers in this assay, from the lowest: compounds 1 and 2 (each within the scatter of the next); then compound 3.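

In this assay, the substituent on the amide nitrogen proves to be a place where the read-out can move sharply: a number 100 percentage points higher from compound 2 to compound 3 (beyond the scatter), with cyclobutyl in place of cyclopentyl as the only difference. Among the compounds shown here, this is the first step that can be read, and it shows that a change confined to the size of this carbon ring is enough to separate no inhibition from a large effect at this dose. Nothing measured alongside the step accounts for it.

Going by these compounds, whether the effect is particular to cyclobutyl or extends to other small groups on this nitrogen, such as cyclopropyl or isopropyl, remains open. On these data alone, as the read-out comes from a single dose and is not a potency, how compound 3 behaves at lower doses also remains open.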